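A few compounds are considered here, and "the series" means these few. Any claim that something is new, unique, unknown or untested is made for them only; others in the source may bear on it.

Measured compounds:
Compound 1 `C=C1C[C@]23C[C@@]1(O)CC[C@H]2c1ccc(OS(=O)(=O)c2ccc(C)cc2)c(C)c1[C@@H]3Cn1cc(-c2ccc(Br)cc2)nn1`, in a functional assay on A549 cells (Homo sapiens) for cytotoxicity, read by MTT assay, with a stated time of 4 days (a lower number here means a stronger inhibitor, a higher number a weaker inhibitor), compound 1 gives a limit of the assay, > 20000 nM.
Compound 2 `C=C1C[C@]23C[C@@]1(O)CC[C@H]2c1ccc(OS(=O)(=O)c2ccc(C)cc2)c(C)c1[C@@H]3Cn1cc(-c2ccc(C)cc2)nn1`, in this assay compound 2 gives a limit of the assay, > 20000 nM.

Compound 2 stands at the limit of this assay, not at a measured number. Among the measured compounds shown here, the one step among the measured compounds, a step that the two limits leave unreadable from compound 1 to compound 2, runs between two limits and so has no readable size. That is the whole of the evidence: the limit of > 20000 nM in this assay, at which 2 of the 2 values shown sit.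

Compound 3 `C=C1C[C@]23C[C@@]1(O)CC[C@H]2c1ccc(OS(=O)(=O)c2ccc(C)cc2)c(C)c1[C@@H]3Cn1cc(-c2ccc(F)cc2)nn1` differs from compound 2 as follows: fluoro in place of methyl on an aromatic carbon. Both measured compounds, compound 1 and compound 2, share this core and sit at the limit, so the step from bromo to methyl on the same aromatic carbon gave no readable movement, and the step to fluoro at that carbon is expected to leave compound 3 at the same limit. The expected step that the limit leaves unreadable from compound 2 to compound 3 is therefore none beyond the scatter. Compound 3 is expected to give 30000 nM in this assay, within 10000 nM to 100000 nM, most likely reported as a limit only.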

Compound 3, half-maximal inhibitory concentration: > 20000 nM
Compound 3: a limit, no number; the forecaster's own chance of this, stated with the estimate: 85%; the middle value is on the limit's open side.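

In this assay compound 3 gives > 20000 nM, a limit of the assay and not a number. The steps from compound 1 and from compound 2 to compound 3 each run between two limits, and neither can be read. The compounds shown leave open whether any group at this aromatic carbon changes the cytotoxicity, with no measured number among them: the limit of > 20000 nM in this assay, at which 3 of the 3 values shown sit.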